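Notes on the step from compound 3 to compound 4

The source may hold more compounds than are shown below. What is called first, only, known or untested is meant among the compounds shown, and "the series" means these compounds.

- compound 1 `COc1cc(CNCc2ccncc2)ccc1OCc1ccccc1F`: 5100 nM
- compound 2 `COc1cc(CNCc2ccncc2)ccc1OCc1ccc(F)cc1`: 6400 nM
- compound 3 `COc1cc(CNCc2ccc(C(=O)O)cc2)ccc1OCc1ccc(Cl)nc1`: "nd(insoluble)" (no result reported)

All three entries come from a functional assay on HeLa cells (Homo sapiens) for inhibition, with a stated time of 72 h; on this read-out higher numbers stand for an effect only at larger amounts of compound and lower numbers for an effect already at smaller amounts. There is no number for compound 3, so it has no place on the scale and gives no starting point. Compound 4 `COc1cc(CNCc2cccnc2)ccc1OCc1ccc(Cl)nc1` differs from it as follows: pyridin-3-yl in place of 4-carboxyphenyl on a saturated chain carbon bound to an amine nitrogen. Going by the values given here, the only measured step, a 1.3-fold higher number from compound 1 to compound 2 (0.10 log units; within the scatter), concerns a different place in the structure and stays within the scatter. Among the compounds with values here, it therefore says nothing about the size of this change, and no step from compound 3 can be expected. The nearest anchors are compound 1 at 5100 nM and compound 2 at 6400 nM. For compound 4 the expected value is 5000 nM, with an estimated range of 1800 nM to 15000 nM.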

Compound 4, half-maximal effective concentration: 5000 nM
Estimate against measurement, compound 4: no gap at the digits printed, and the stated range covers the measured number.
By their numbers in this assay, from the lowest: compounds 4, 1 and 2 (each within the scatter of the next).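

No new step can be read from compound 3 to compound 4: compound 3 has no number on this scale. No measured evidence bears on the result. The compounds shown leave open what pyridin-3-yl in place of 4-carboxyphenyl does on its own.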